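The source may hold more compounds than are shown below. What is called first, only, known or untested is meant among the compounds shown, and "the series" means these compounds.

Of the compounds shown here, three of a shared core have been measured in a functional assay on the whole organism (strain Wistar) for inhibition, with Rattus norvegicus as the target, read by paw edema, with a stated time of 3 h, at a dose of 100 mg/kg; a lower number here means less inhibition, a higher number more inhibition at the dose given (going by the name of the read-out). Compound 1 `COc1cc2c(cc1OC)C(CC(=O)O)CC2` carries a free carboxylic acid and gives 27.5%. Compound 2 `COc1cc2c(cc1OC)C(CC(=O)Nc1cccc(Cl)c1)CC2`, with a (3-chlorophenyl)amino on the carbonyl carbon, gives 24.6%, a change of a number 2.9 percentage points lower from compound 1 to compound 2 (within the scatter). Compound 3 `COc1cc2c(cc1OC)C(CC(=O)Nc1cccc(C)c1)CC2`, with a (3-methylphenyl)amino in that place, gives 37.7%, the highest of the three numbers: the rise of a number 10.2 percentage points higher from compound 1 to compound 3 (beyond the scatter) and of a number 13.1 percentage points higher from compound 2 to compound 3 (beyond the scatter) both lie beyond the scatter, so compound 3 stands clearly above compound 1 and compound 2.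

Compound 4 `COc1cc2c(cc1OC)C(CC(=O)Nc1ccc(C)cc1)CC2` has not been measured. It differs from compound 3 in one place: 4-methylphenyl in place of 3-methylphenyl on an amide-type nitrogen. Going by the values given here, no measured step bears directly on this change; the steps so far swap the group on the carbonyl carbon or exchange chloro for methyl, and none moves a methyl from one site to another on the aromatic ring. The step of a number 1.7 percentage points lower from compound 3 to compound 4 (within the scatter) is therefore expected to stay within the scatter, with no direction favoured. Compound 4 is estimated at 36%, in the range 24% to 48%.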

Compound 4, a percentage reported as inhibition, in the whole organism at one dose (the size of the read-out at that dose, not a potency): 34.8%
The estimate for compound 4 lay 1.2 percentage points above the measured number, within the range that was stated.
By their numbers in this assay, from the lowest: compounds 2, 1, 4 and 3 (each within the scatter of the next, the first and the last beyond it).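

In this assay, moving the methyl from 3-methylphenyl to 4-methylphenyl on the amide-type nitrogen gives a number 2.9 percentage points lower from compound 3 to compound 4 (within the scatter), so this first change of methyl site within the ring leaves the two compounds indistinguishable. The 4-methylphenyl group also stands clear of the 3-chlorophenyl group, with a number 10.2 percentage points higher from compound 2 to compound 4 (beyond the scatter), so the separation first seen with the 3-methylphenyl compound also holds for this methyl isomer. The amide's lead over the free acid does not carry over in the same way, however: a number 7.3 percentage points higher from compound 1 to compound 4 (within the scatter) separates neither compound from the other, whereas compound 3 stood beyond the scatter from compound 1.

The compounds shown leave open how an unsubstituted phenyl, or an ethyl or methoxy group in place of the methyl, would read at this position. No evidence is available to explain any of these differences.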